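Aryl swap at the saturated ring carbon of the shared core

The source may report more compounds than this note shows. Statements on the series, on what has been measured and on what is new or still open speak of the compounds shown alone.

Measured so far:
- compound 1 `O=C1CCCC2=C1C(c1ccc(Cl)cc1)C=C(c1ccccc1)N2`: 8.21%
- compound 2 `CC1(C)CC(=O)C2=C(C1)NC(c1ccccc1)=CC2c1ccc([N+](=O)[O-])cc1`: "not active" (no number reported)
- compound 3 `COc1ccc(C2C=C(c3ccccc3)NC3=C2C(=O)CC(C)(C)C3)cc1`: "not active" (no number reported)

In an assay on isolated protein for inhibition of glucose-6-phosphatase catalytic subunit 1 (Homo sapiens), read by inositol phosphate accumulation, with a stated time of 30 min, tested at 100 uM (on this read-out higher numbers stand for more inhibition at the one concentration tested (going by the name of the read-out) and lower numbers for less inhibition), compound 1 gives 8.21%, a small read-out. Compound 2 is reported in this assay as "not active" (no number reported), without a number. Compound 3 likewise gives "not active" (no number reported) in this assay, so compound 3 has no single number to stand on; it shares this standing with one further entry of the set, and nothing in the numbers shown separates it from the others. Going by the values given here, no step between two measured compounds is given here.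

Compound 4 `CC1(C)CC(=O)C2=C(C1)NC(c1ccccc1)=CC2c1ccco1` differs from compound 3 by furan-2-yl in place of 4-methoxyphenyl on a saturated ring carbon. The rest of the core is unchanged. Among the compounds with values here, with compound 3 reported as "not active" (no number reported) and compound 1 at 8.21%, no step of a size beyond the scatter is expected for compound 4 in this assay; a read-out near the bottom of the scale is expected. Compound 4 is estimated at 5% in this assay, with an expected range from 0% to 15%, and a fair chance that again only a qualitative result and no number is reported.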

Compound 4, a percentage reported as inhibition, at one concentration (the size of the read-out at that concentration, not a potency): 11.4%
Compound 4: middle estimate off by 6.4 percentage points, on the low side; measured number inside the range.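

Going by these compounds alone, compound 3 is reported without a number, so no step from it to compound 4 can be read. The compounds shown leave open whether any aryl swap at this saturated ring carbon moves the read-out beyond the usual scatter. No evidence bears on this result.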